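This account rests on a few compounds, and the source may have more. Where it says the series, first, only, none or still open, it means among the compounds named here.

The three measured compounds share one core, differing only in the group on an oxygen on a saturated carbon. Compound 1 `COc1ccc(C2=C(c3cc(OC)c(OC)c(OC)c3)C(=O)C(O[SiH2]C(C)(C)C)C2)cc1OC(C)C` carries there a group of 5 heavy atoms (4 carbon, 1 silicon; no ring). In an ADME assay on MIA PaCa-2 cells (Homo sapiens) for cytotoxicity, read by MTT assay, with a stated time of 72 h (a higher number here means a weaker inhibitor, a lower number a stronger inhibitor), compound 1 gives > 100 ug/mL, which is a limit of the assay rather than a number. Compound 2 `COc1ccc(C2=C(c3cc(OC)c(OC)c(OC)c3)C(=O)C(OC(C)=O)C2)cc1OC(C)C` carries acetyl on that oxygen, and in this assay compound 2 gives > 100 ug/mL, again only a limit. Compound 3 `COc1ccc(C2=C(c3cc(OC)c(OC)c(OC)c3)C(=O)C(O)C2)cc1OC(C)C` carries hydrogen there, and in this assay compound 3 gives > 100 ug/mL, also a limit. Because (the limit of > 100 ug/mL in this assay, at which 3 of the 3 values shown sit), the steps a step that the two limits leave unreadable from compound 1 to compound 2, a step that the two limits leave unreadable from compound 1 to compound 3 and a step that the two limits leave unreadable from compound 2 to compound 3 cannot be read as numbers. Compound 1 therefore stands at the limit, as do its two companions. Compound 4 `COc1cc(C2=C(c3ccc(SC)cc3)CC(O[SiH2]C(C)(C)C)C2=O)cc(OC)c1OC` differs from compound 1 at another place: 4-(methylsulfanyl)phenyl in place of 3-isopropoxy-4-methoxyphenyl on a double-bonded ring carbon. Within the data shown here, no measured step touches this change, so none gives a size or direction for it. With only limits to lean on, compound 4 is estimated at 40 ug/mL, expected to fall between 5 ug/mL and 100 ug/mL. That estimate means an expected step of an at least 2.5-fold lower number from compound 1 to compound 4 (0.39 log units; beyond the scatter), with a real chance that compound 4 too reports only a limit.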

Compound 4, half-maximal inhibitory concentration: < 1 ug/mL
Compound 4 ended at the assay's limit; the forecaster's own chance of this, stated with the estimate: 50%; middle value at least 40-fold (1.60 log units) away from the limit.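

In this assay, putting 4-(methylsulfanyl)phenyl in place of 3-isopropoxy-4-methoxyphenyl on the double-bonded ring carbon gives an at least 100-fold lower number from compound 1 to compound 4 (2.00 log units; beyond the scatter). Compound 4 gives < 1 ug/mL, which is a limit of the assay and not a number. The earlier compounds varied only the group on the oxygen and all sat at one limit, whereas this ring carbon is the first place among the compounds shown where a change moves the read-out.

Still open, as far as these compounds go, is which part of the swap matters, the sulfur or the loss of the isopropoxy group, and a 4-methoxyphenyl or 4-aminophenyl group at this position would help to separate them. Also open, from the compounds shown here alone, is whether the effect holds with acetyl or hydrogen on the oxygen in place of the group of 5 heavy atoms.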